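A few compounds are considered here, and "the series" means these few. Any claim that something is new, unique, unknown or untested is made for them only; others in the source may bear on it.

Measured so far:
compound 1 `CC(=O)NC1C2CC3CC1CC(C2)C31OO[C@]2(CC[C@@H](c3ccc(OCC(=O)O)cc3)CC2)O1`, 1.8
compound 2 `CC(C)(Oc1ccc([C@H]2CC[C@]3(CC2)OOC2(O3)C3CC4CC(C3)CC2C4)cc1)C(=O)O`, 3.1

In a physicochemical assay for lipophilicity, read by HPLC, at pH 7.4 (a higher number here means a more lipophilic compound, a lower number a more polar compound), compound 2 gives 3.1, the higher of the two numbers measured; compound 1 gives 1.8, a gap beyond the usual scatter. Compound 3 `O=C(O)CCCOc1ccc([C@H]2CC[C@]3(CC2)OOC2(O3)C3CC4CC(C3)CC2C4)cc1` has not yet been measured in this assay. It differs from compound 2 in one place: 3-carboxypropyl in place of 1-carboxy-1-methylethyl on an oxygen on an aromatic ring. Within the data shown here, no measured pair shows this change, so the size of the step is open; a small rise, near the edge of the scatter, is expected, a number 0.30 log units higher from compound 2 to compound 3 (within the scatter). Compound 3 is therefore estimated at 3.4, between 2.9 and 3.9.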

Compound 3, distribution coefficient: 3.6
Beside the measured number, compound 3's estimate is 0.20 log units below it, and the stated range covers the measured number.
By their numbers in this assay, from the lowest: compound 1; then compound 2; then compound 3.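

In this assay, putting 3-carboxypropyl in place of 1-carboxy-1-methylethyl on an oxygen on an aromatic ring gives a number 0.50 log units higher from compound 2 to compound 3 (beyond the scatter). The number at this position therefore depends on how the atoms of the group are joined, since both groups have the same counts of heavy atoms, donors and acceptors. No available evidence bears on the reason for this step.

From the compounds shown here alone, whether a longer chain ending in a carboxylic acid, or an amine in place of that acid, would shift the number further remains open. Going by these compounds, this change also rests on a single pair, so its size on another core is unknown.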